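Chlorine to ethyl on the amide nitrogen

A few compounds are considered here, and "the series" means these few. Any claim that something is new, unique, unknown or untested is made for them only; others in the source may bear on it.

Compound 1 `Cc1ccc(N2C(=O)C/C(=C\c3cccc(C(=O)Nc4cccc(F)c4)c3)C2=O)cc1` gives 96900 nM in an ADME assay on SW480 cells (Homo sapiens) for cytotoxicity, read by MTT assay, with a stated time of 72 h (on this read-out lower numbers stand for stronger inhibition and higher numbers for weaker inhibition), and compound 2 `CCCCCN1C(=O)C/C(=C\c2cccc(C(=O)Nc3cccc(CC)c3)c2)C1=O` gives 83300 nM in this assay. Compound 3 `Cc1ccc(N2C(=O)C/C(=C\c3cccc(C(=O)Nc4ccc(Cl)cc4)c3)C2=O)cc1` is reported in this assay only as a limit, > 100000 nM, not as a number. Compound 3 thus sits at the limit of > 100000 nM in this assay, at which 1 of the 3 values shown sits. For the measured compounds named here, the only measured step on the amide-bound ring, an at least 1.0-fold higher number from compound 1 to compound 3 (0.01 log units; that floor lies within the scatter), stays within the scatter. Compound 4 `CCc1cccc(NC(=O)c2cccc(/C=C3\CC(=O)N(c4ccc(C)cc4)C3=O)c2)c1` differs from compound 3 by 3-ethylphenyl in place of 4-chlorophenyl on an amide-type nitrogen. Compound 2 carries the same 3-ethylphenyl beside a different group on the imide nitrogen. No step beyond the scatter is expected in this assay. Compound 4 is therefore expected near 90000 nM, between 50000 nM and 160000 nM, an estimated step of an at least 1.1-fold lower number from compound 3 to compound 4 (0.04 log units; that floor lies within the scatter) that may again end at the limit.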

Compound 4, half-maximal inhibitory concentration: 65300 nM
Compound 4: the middle estimate sits 1.4-fold (0.14 log units) above what was measured; the measured number falls inside the stated range.
By their numbers in this assay, from the lowest: compounds 4, 2 and 1 (each within the scatter of the next). At a limit, above all of these: compound 3.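

In this assay, 3-ethylphenyl in place of 4-chlorophenyl on an amide-type nitrogen gives an at least 1.5-fold lower number from compound 3 to compound 4 (0.18 log units; that floor lies within the scatter), so this change yields a measured number, though its floor shows no step beyond the scatter. Ethyl in place of fluoro on an aromatic carbon gives a 1.5-fold lower number from compound 1 to compound 4 (0.17 log units; within the scatter), and 4-methylphenyl in place of pentyl on an amide-type nitrogen in a ring gives a 1.3-fold lower number from compound 2 to compound 4 (0.11 log units; within the scatter), so neither change leaves the scatter. Compound 3 remains a limit, not a number: the limit of > 100000 nM in this assay, at which 1 of the 4 values shown sits.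

Going by these compounds, whether an amine, a carboxylic acid or a longer chain on the amide-bound ring would give a step beyond the scatter stays open.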